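Swapping the aryl group of compound 3

This account rests on a few compounds, and the source may have more. Where it says the series, first, only, none or still open, it means among the compounds named here.

In a functional assay on HepG2 cells (Homo sapiens) for cytotoxicity, read by MTT assay, with a stated time of 72 h (on this read-out higher numbers stand for weaker inhibition and lower numbers for stronger inhibition), compound 3 `CNC(=O)c1cc(Oc2ccc(C3=NNC(c4ccc(Cl)c(Cl)c4)C3)cc2)ccn1` gives 14400 nM. Compound 2 `CNC(=O)c1cc(Oc2ccc(C3=NNC(c4ccc(OC)cc4)C3)cc2)ccn1` gives 9640 nM, and the comparison between them is a 1.5-fold higher number from compound 2 to compound 3 (0.17 log units; within the scatter). Compound 1 `CNC(=O)c1cc(Oc2ccc(C3=NNC(c4cccc(Br)c4)C3)cc2)ccn1` gives 1850 nM, which leaves a clear gap: a 7.8-fold higher number from compound 1 to compound 3 (0.89 log units; beyond the scatter). Compound 4 `CNC(=O)c1cc(Oc2ccc(C3=NNC(c4ccc(F)cc4)C3)cc2)ccn1` has 4-fluorophenyl in place of 3,4-dichlorophenyl on a saturated ring carbon. Among the measured compounds shown here, the measured swaps at this same carbon are the only guide, and none of the tested compounds carries fluorine. The larger steps all start from compound 1, including a 5.2-fold higher number from compound 1 to compound 2 (0.72 log units; beyond the scatter), so a small expected shift seems the safer reading: a 1.6-fold lower number from compound 3 to compound 4 (0.20 log units; within the scatter). For compound 4 the estimated value is 9000 nM, within an expected range from 3500 nM to 22000 nM.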

Compound 4, half-maximal inhibitory concentration: 5280 nM
Estimate against measurement, compound 4: 1.7-fold (0.23 log units) above; low and high end bracket the measured number.
By their numbers in this assay, from the lowest: compound 1; then compounds 4, 2 and 3 (each within the scatter of the next, the first and the last beyond it).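

Compound 4 shows that a halogen at this carbon does not by itself fix the number in this assay: replacing 3,4-dichlorophenyl with 4-fluorophenyl gives a 2.7-fold lower number from compound 3 to compound 4 (0.44 log units; beyond the scatter). The change from 4-methoxyphenyl, a 1.8-fold lower number from compound 2 to compound 4 (0.26 log units; within the scatter), cannot be told apart from the scatter. The 3-bromophenyl group of compound 1 still gives the lowest number, with a 2.9-fold higher number from compound 1 to compound 4 (0.46 log units; beyond the scatter).

Nothing available explains why these aryl groups differ. From the compounds shown here alone, how an aryl ring carrying an amine or a carboxylic acid would behave at this carbon remains open.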